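Notes on compound 4: cyclopropylmethoxy in place of fluoro

A few compounds are considered here, and "the series" means these few. Any claim that something is new, unique, unknown or untested is made for them only; others in the source may bear on it.

Measured so far:
Compound 1 `O=c1cc(/C=C/c2ccc(OC(F)(F)F)cc2)oc2ccccc12`; in a functional assay on A549 cells (Homo sapiens) for antiproliferative activity, read by MTT assay, with a stated time of 12 h (a lower number here means a stronger inhibitor, a higher number a weaker inhibitor), compound 1 gives 15600 nM.
Compound 2 `COc1cc(OC)c2c(=O)cc(/C=C/c3ccc(F)cc3)oc2c1`; in this assay compound 2 gives 18600 nM.
Compound 3 `COc1cc(OC)c2c(=O)cc(/C=C/c3ccncc3)oc2c1`; in this assay compound 3 reaches only a limit, > 40000 nM.

Compound 2 holds the highest of the two numbers in this assay, with compound 1 within the scatter of it. Compound 4 `COc1cc(OC)c2c(=O)cc(/C=C/c3ccc(OCC4CC4)cc3)oc2c1` differs from compound 2 by cyclopropylmethoxy in place of fluoro on an aromatic carbon. Going by the values given here, the only measured step, an at least 2.1-fold higher number from compound 2 to compound 3 (0.33 log units; beyond the scatter), exchanges the whole terminal ring and runs into (the limit of > 40000 nM in this assay, at which 1 of the 3 values shown sits), so it bears only loosely on a substituent change on a retained ring. Compounds 1 and 2, on different cores, carry trifluoromethoxy and fluoro and sit within the scatter of each other. A small step is therefore expected: a 1.4-fold lower number from compound 2 to compound 4 (0.16 log units; within the scatter). Compound 4 is estimated at 13000 nM, within a range from 4500 nM to 40000 nM.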

Compound 4, half-maximal inhibitory concentration: 20900 nM
Estimate against measurement, compound 4: 1.6-fold (0.21 log units) below; low and high end bracket the measured number.
By their numbers in this assay, from the lowest: compounds 1, 2 and 4 (each within the scatter of the next). At a limit, above all of these: compound 3.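

In this assay, the aromatic carbon para to a large group takes cyclopropylmethoxy in place of fluoro without a readable change (a 1.1-fold higher number from compound 2 to compound 4 (0.05 log units; within the scatter)). The position therefore accepts 5 heavy atoms, a three-membered ring and a hydrogen-bond acceptor where compound 2 carries a single fluorine, at least on this shared core. Nothing measured here speaks to why the two groups read alike.

From the compounds shown here alone, whether an amine or a carboxylic acid at this carbon would shift the number beyond the scatter remains open. So does the effect of a longer chain in place of cyclopropylmethoxy.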